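Dropping One Chloro Group From an Aryl Urea

The compounds below may be only part of what the source reports. "The series", "measured", "known", "first", "only" and "open" are said of these compounds alone.

Among the measured compounds shown here, compound 1, whose structure is `Cc1cc(NC(=O)Nc2ccc(Cl)c(Cl)c2)c2ccccc2n1`, is the only member of this small set with an actual number in an ADME assay on BJ cells (Homo sapiens) for cytotoxicity, with a stated time of 72 h; on this read-out lower numbers stand for an effect already at smaller amounts and higher numbers for an effect only at larger amounts of compound: in this assay compound 1 gives 23000 nM. Compound 2, with structure `Cc1cc(NC(=O)Nc2ccc(N(C)C)cc2)c2ccccc2n1`, reaches only a limit of the assay; in this assay compound 2 gives > 25000 nM, a limit rather than a number. Compound 3, with structure `COc1ccccc1NC(=O)Nc1cc(C)nc2ccccc12`, also ends at a limit, giving > 25000 nM in this assay. So compound 1 stands alone as the one compound where the effect could be pinned down, while the other two sit at the limit of > 25000 nM in this assay, at which 2 of the 3 values shown sit.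

Compound 4, with structure `Cc1cc(NC(=O)Nc2cccc(Cl)c2)c2ccccc2n1`, has not yet been measured. It differs from compound 1 by hydrogen in place of chloro on an aromatic carbon. For the measured compounds named here, with no measured pair showing what such a change does in this assay, the expectation rests on the numbers at hand alone. Since two of the three values already sit at a limit, compound 4 is expected to land near that limit as well, and the step of a 1.2-fold higher number from compound 1 to compound 4 (0.09 log units; within the scatter) is estimated to stay within the usual scatter or to be a small shift toward a weaker effect. Compound 4 is therefore expected to give about 28000 nM, within a range of 12000 nM to 60000 nM.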

Compound 4, half-maximal effective concentration: > 25000 nM
Compound 4 ended at the assay's limit (the forecaster's own chance of this, stated with the estimate: 60%); the middle value does not contradict the limit.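

Among the compounds shown here, this is the first pair in the set that differs in one place, so it gives a first direct look at this aromatic carbon, ortho to a chloro group and para to a large group. In this assay, hydrogen in place of chloro there gives an at least 1.0-fold higher number from compound 1 to compound 4 (0.03 log units; that floor lies within the scatter), so the pair shows no firm change, though a larger step remains possible because compound 4 gives only a limit, not a number. Compound 4 also joins the two other compounds that reach the limit: the limit of > 25000 nM in this assay, at which 3 of the 4 values shown sit.

As far as these compounds go, how far the true value of compound 4 lies from that of compound 1 stays open. Also open, from the compounds shown here alone, is what a different group on this same carbon, such as an amine or a carboxylic acid, would do to the read-out.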